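The source may report more compounds than this note shows. Statements on the series, on what has been measured and on what is new or still open speak of the compounds shown alone.

The measured compounds:

Compound 1, `COc1ccc(NC(=O)Nc2cc(C)nc3ccccc23)cc1`. In an ADME assay on HepG2 cells (Homo sapiens) for cytotoxicity, with a stated time of 72 h (a lower number here means that less compound is needed, a higher number that more compound is needed for the effect), compound 1 gives > 25000 nM, which is a limit of the assay rather than a number.
Compound 2, `Cc1cc(NC(=O)Nc2cc(F)ccc2F)c2ccccc2n1`. In this assay compound 2 gives > 25000 nM, again a limit.
Compound 3, `Cc1cc(NC(=O)Nc2ncccc2C)c2ccccc2n1`. In this assay compound 3 gives > 25000 nM, also a limit.

Compound 3 therefore stands nowhere distinct: all three compounds sit at the limit of > 25000 nM in this assay, at which 3 of the 3 values shown sit, and none of them can be ordered against another. The step from compound 3 leads to compound 4, `Cc1cc(NC(=O)Nc2ccc(N)cc2)c2ccccc2n1`, in which the same atoms are joined differently: 4-aminophenyl in place of 3-methylpyridin-2-yl on an amide-type nitrogen. Among the measured compounds shown here, no step between two measured compounds exists here, so the size of this change cannot be read from a measured pair; the only guide is that the three compounds all reach the limit without a number. For the measured compounds named here, on that basis compound 4 is expected to behave like them, with no step in this assay beyond the scatter. The step from compound 3 to compound 4 is estimated as a step that the limit leaves unreadable from compound 3 to compound 4. For compound 4 the expected value in this assay is 30000 nM, with a range from 10000 nM to 100000 nM, and most likely the assay will again report only a limit.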

Compound 4, half-maximal effective concentration: > 25000 nM
Compound 4 was reported as a limit; the forecaster's own chance of this, stated with the estimate: 80%; the middle value is on the limit's open side.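

Compound 4, like compound 3 and compound 1, is reported only as a limit, so neither step to compound 4 can be read. The compounds shown leave open how much of any of them is needed for the effect in this assay, for each value is only a limit: the limit of > 25000 nM in this assay, at which 4 of the 4 values shown sit.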